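Ortho substituent swap on the thiourea aryl, working notes

The compounds below may be only part of what the source reports. "The series", "measured", "known", "first", "only" and "open" are said of these compounds alone.

Measured so far:
compound 1, `NC(=O)c1c(NC(=O)c2ccccc2Br)sc2c1CCN(C(=S)Nc1ccccc1Cl)C2`: 46900 nM in a functional assay on HeLa cells (Homo sapiens) for antiproliferative activity, with a stated time of 24 h; a higher number here means a weaker inhibitor, a lower number a stronger inhibitor
compound 2, `NC(=O)c1c(NC(=O)c2ccccc2I)sc2c1CCN(C(=S)Nc1ccccc1Cl)C2`: recorded only as a limit of this assay, > 50000 nM
compound 3, `Cc1ccccc1C(=O)Nc1sc2c(c1C(N)=O)CCN(C(=S)Nc1ccccc1Cl)C2`: 35300 nM

Compound 1 holds the highest of the two numbers in this assay; compound 3 is the nearest, with a 1.3-fold lower number from compound 1 to compound 3 (0.12 log units; within the scatter), so the two cannot be told apart. Compound 2 is set apart only by being a limit, (the limit of > 50000 nM in this assay, at which 1 of the 3 values shown sits). The step of an at least 1.0-fold higher number from compound 1 to compound 2 (0.02 log units; that floor lies within the scatter) and the step of an at least 1.4-fold lower number from compound 2 to compound 3 (0.15 log units; that floor lies within the scatter) complete the set; every measured step sits at the benzamide aryl and none of them exceeds the scatter.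

Compound 4, `NC(=O)c1c(NC(=O)c2ccccc2Br)sc2c1CCN(C(=S)Nc1ccccc1C(F)(F)F)C2`, differs from compound 1 in another place: trifluoromethyl in place of chloro on an aromatic carbon. For the measured compounds named here, no measured step touches the aryl on the thiourea side, so nothing among the three compounds bears directly on this change. What the measured steps do show is that single exchanges of an ortho group on an aryl of this core have moved the read-out by no more than the scatter. On that basis the expected step is a 1.0-fold lower number from compound 1 to compound 4 (0.02 log units; within the scatter), a change not expected to exceed the scatter. Compound 4 is therefore estimated at 45000 nM, with a range from 15000 nM to 140000 nM.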

Compound 4, half-maximal inhibitory concentration: 39600 nM
The estimate for compound 4 lay 1.1-fold (0.06 log units) above the measured number, within the range that was stated.
By their numbers in this assay, from the lowest: compounds 3, 4 and 1 (each within the scatter of the next). At a limit, above all of these: compound 2.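

For the compounds shown here, the one step on the thiourea-side aryl, read in this assay, is a 1.2-fold lower number from compound 1 to compound 4 (0.07 log units; within the scatter), so compound 1 and compound 4 cannot be told apart. The earlier steps shown here all sat at the benzamide aryl, and this result extends the same finding to the other aryl of the shared core: exchanging chloro for trifluoromethyl, a group with more heavy atoms and no hydrogen-bond donors or acceptors on either side of the change, at this place ortho to a large group leaves the read-out within the scatter. Nothing measured here accounts for this absence of a resolved change, and the one available observation concerns only the limit recorded for compound 2, not this position.

As far as these compounds go, two halogen-type or fluorinated groups on this aryl say little about a group of a different kind, so it stays open whether an amine, a carboxylic acid or a longer chain such as n-butyl in place of the chloro would move the read-out beyond the scatter. From the compounds shown here alone, it also stays open whether the 2-(trifluoromethyl)phenyl group would give the same result when paired with a benzamide aryl other than that of compound 4.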